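A few compounds are considered here, and "the series" means these few. Any claim that something is new, unique, unknown or untested is made for them only; others in the source may bear on it.

Measured so far in a functional assay on CHO-K1 cells for antagonist activity at C-X-C chemokine receptor type 3 (Homo sapiens), read by FLIPR, with a stated time of 10 min; on this read-out lower numbers stand for stronger inhibition and higher numbers for weaker inhibition:

Compound 1 `Cc1nc(C)n(CC(=O)N2CCN(c3sc(C(F)(F)F)nc3-c3cnc(OC(C)C)nc3)C[C@H]2C)n1` gives 3.4 nM.
Compound 2 `CCCc1ncc(-c2nc(C(F)(F)F)sc2N2CCN(C(=O)Cn3nc(C)nc3C)[C@H](C)C2)cn1` gives 4.4 nM.

For the measured compounds named here, only one step connects these two: a 1.3-fold higher number from compound 1 to compound 2 (0.11 log units; within the scatter). Compound 2 and compound 1 thus sit within the usual scatter of each other, so the numbers shown do not set one apart from the other.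

Compound 3 `Cc1nc(C)n(CC(=O)N2CCN(c3sc(C(F)(F)F)nc3-c3cnc(C4CC4)nc3)C[C@H]2C)n1` differs from compound 2 in one place: cyclopropyl in place of propyl on an aromatic carbon. The group sits on an aromatic carbon of a six-membered aromatic ring with two nitrogen, between two ring nitrogen atoms, para to a large group, the same place that was changed in the step from compound 1 to compound 2. That step stayed within the scatter, so a small group swapped at this position has so far left the potency unchanged. The step from compound 2 to compound 3 is therefore expected to stay within the scatter as well, with no clear direction: a 1.0-fold higher number from compound 2 to compound 3 (0.01 log units; within the scatter). For compound 3 the estimate is 4.5 nM, with a range from 1.5 nM to 13 nM.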

Compound 3, half-maximal inhibitory concentration: 3.5 nM
Beside the measured number, compound 3's estimate is 1.3-fold (0.11 log units) above it; low and high end bracket the measured number.
By their numbers in this assay, from the lowest: compounds 1, 3 and 2 (each within the scatter of the next).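

Swapping propyl for cyclopropyl, which keeps the same count of heavy atoms but adds a three-membered ring, gives a 1.3-fold lower number from compound 2 to compound 3 (0.10 log units; within the scatter) in this assay. Cyclopropyl in place of isopropoxy gives a 1.0-fold higher number from compound 1 to compound 3 (0.01 log units; within the scatter), so at this place on the six-membered aromatic ring, an open carbon chain, an oxygen-linked group and a small carbon ring all give numbers that cannot be told apart. Nothing available here accounts for why these three groups read alike.

As far as these compounds go, whether an amine, a carboxylic acid or a chain longer than propyl at this place would also stay within the scatter remains open. So does whether these swaps would read the same way if the rest of the molecule were different, as all three compounds share everything else.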